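Replacing a fluorinated phenyl amide with a dimethylpyridyl amide

This account rests on a few compounds, and the source may have more. Where it says the series, first, only, none or still open, it means among the compounds named here.

Measured compounds:
compound 1, `COc1ccc2nc(C)cc(OCC(=O)Nc3ccccc3)c2c1`, 4.28
compound 2, `COc1ccc2nc(C)cc(OCC(=O)Nc3c(C)cccc3C)c2c1`, 4.55
compound 3, `COc1ccc2nc(C)cc(OCC(=O)Nc3cc(C)c(F)c(C)c3)c2c1`, 5.5

In a physicochemical assay for lipophilicity, read by HPLC, in phosphate buffer, measured as chromatographic lipophilicity, at pH 7.4 (on this read-out lower numbers stand for lower lipophilicity and higher numbers for higher lipophilicity), compound 3 stands highest of the three numbers, its nearest neighbour being compound 2, which lies a number 0.95 log units higher from compound 2 to compound 3 (beyond the scatter), and the furthest compound 1, which lies a number 1.22 log units higher from compound 1 to compound 3 (beyond the scatter). The two dimethyl-bearing anilides differ only in the single fluorine and in the placement of the methyl groups, yet that step was a number 0.95 log units higher from compound 2 to compound 3 (beyond the scatter), while the step from the unsubstituted phenyl was a number 0.27 log units higher from compound 1 to compound 2 (within the scatter).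

Compound 4, `COc1ccc2nc(C)cc(OCC(=O)Nc3c(C)cncc3C)c2c1`, is not yet measured. It differs from compound 3 as follows: 3,5-dimethylpyridin-4-yl in place of 4-fluoro-3,5-dimethylphenyl on an amide-type nitrogen. Within the data shown here, no measured step here involves a ring nitrogen, so the measured steps speak only indirectly: they show that the fluorine and methyl pattern of compound 3 carried it well above compounds 1 and 2, and compound 4 gives that fluorine up while keeping two methyl groups. Exchange of a carbon ring for an aromatic ring holding one nitrogen is generally accompanied by a clear fall in this assay, beyond the scatter. Compound 4 is therefore expected to sit far below compound 3, by about a number 2.20 log units lower from compound 3 to compound 4 (beyond the scatter), and also below compound 2. The estimate for compound 4 is 3.3, with a range from 2.7 to 3.9.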

Compound 4, distribution coefficient: 3.01
Compound 4: middle estimate off by 0.29 log units, on the high side; low and high end bracket the measured number.
By their numbers in this assay, from the lowest: compound 4; then compounds 1 and 2 (each within the scatter of the next); then compound 3.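

In this assay, among these compounds, the exchange of 4-fluoro-3,5-dimethylphenyl for 3,5-dimethylpyridin-4-yl on the amide-type nitrogen produces the largest step seen at this position (a number 2.49 log units lower from compound 3 to compound 4 (beyond the scatter)), and it shows for the first time that a change here can take the number well below that of the unsubstituted phenyl (a number 1.27 log units lower from compound 1 to compound 4 (beyond the scatter)). Compound 2 and compound 4 each carry two methyl groups, yet the step between them is also beyond the scatter (a number 1.54 log units lower from compound 2 to compound 4 (beyond the scatter)), so keeping two methyl groups on the ring did not hold the number up once the ring contained a hetero atom. Nothing shown here accounts for the size of these steps.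

The compounds shown leave open how an unmethylated pyridin-4-yl or a pyrimidin-5-yl group would read at this position, and how the same ring would read with a single methyl group. A 3,5-dimethylphenyl group would also be needed to separate the share of the fluorine from that of the methyl groups in the high number of compound 3.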